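This account rests on a few compounds, and the source may have more. Where it says the series, first, only, none or still open, it means among the compounds named here.

In an assay on SH-SY5Y cells for inhibition of Voltage-dependent N-type calcium channel subunit alpha-1B (Homo sapiens), read by FLIPR and calcium flux, with stated times of 600 s and 300 s, in the presence of a further agent that is not named here (on this read-out lower numbers stand for stronger inhibition and higher numbers for weaker inhibition), compound 1 `NCCCOc1ccc(CNc2nc3ccc(Oc4ccc(O)cc4)cc3s2)cc1` gives 205000 nM. Compound 2 `N=C(N)NCCCOc1ccc(CNc2nc3ccc(Oc4ccc(O)cc4)cc3s2)cc1`, which carries a guanidine-like group on the amine nitrogen, gives 253000 nM; the step of a 1.2-fold higher number from compound 1 to compound 2 (0.09 log units; within the scatter) changes little, so compound 1 and compound 2 sit within the scatter of each other. Compound 3 `NCCCOc1ccc(CNc2nc3ccc(Oc4ccccc4)cc3s2)cc1` differs from compound 1 by hydrogen in place of hydroxy on an aromatic carbon. Going by the values given here, no measured step touches that position, so nothing here shows how the hydroxy contributes. Compound 3 is therefore expected to stay close to compound 1, with a step of a 1.5-fold higher number from compound 1 to compound 3 (0.17 log units; within the scatter), and is estimated at 300000 nM with a range from 100000 nM to 1000000 nM.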

Compound 3, half-maximal inhibitory concentration: 218000 nM
The estimate for compound 3 lay 1.4-fold (0.14 log units) above the measured number; low and high end bracket the measured number.
By their numbers in this assay, from the lowest: compounds 1, 3 and 2 (each within the scatter of the next).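

Going from 4-hydroxyphenoxy to phenoxy gives a 1.1-fold higher number from compound 1 to compound 3 (0.03 log units; within the scatter) and so shows that, in this pair, the number does not depend on the hydroxy on this aromatic carbon. Going by these compounds alone, the earlier step concerned the amine nitrogen, so this is the first reading of this position, and it too stays within the scatter. No supporting measurement bears on this result.

From the compounds shown here alone, whether an amine, a methoxy group or a carboxylic acid at this position would shift the number remains open. Also open, going by these compounds, is whether a longer chain carrying the amine would shift it.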